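The source may report more compounds than this note shows. Statements on the series, on what has been measured and on what is new or still open speak of the compounds shown alone.

Measured compounds:
- compound 1, `N=C(N)Nc1cc(-c2cccc(Cl)c2)ccn1`: "not determined" (no result reported)
- compound 2, `N=C(N)Nc1cc(-c2ccc(Cl)cc2)ccn1`: "not determined" (no result reported)
- compound 3, `N=C(N)Nc1cccc(-c2ccccc2)n1`: > 30000 nM

In a functional assay on PBMC cells (Homo sapiens) for inhibition, read by ELISA, with a stated time of 24 h (a higher number here means a weaker inhibitor, a lower number a stronger inhibitor), compound 1 has no reported result, "not determined" (no result reported). Compound 2 likewise has no reported result in this assay, "not determined" (no result reported). For compound 3 this assay gives only a limit, > 30000 nM, not a number; the compound shows no inhibition up to the highest concentration tested, so the true value lies somewhere beyond that point. Among the measured compounds shown here, compound 3 is thus the only compound of the three with any reading, and that reading is a limit, shared by the limit of > 30000 nM in this assay, at which 1 of the 3 values shown sits.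

Compound 4, `N=C(N)Nc1cccc(-c2ccccc2Cl)n1`, differs from compound 3 by one change: chloro in place of hydrogen on an aromatic carbon. For the measured compounds named here, no measured pair shows what such a change does in this assay, so there is no step to lean on. With the only reference point being a limit, compound 4 is expected to sit near that same limit, and the step that the limit leaves unreadable from compound 3 to compound 4 is expected to be none beyond the scatter. Compound 4 is therefore estimated at 40000 nM, within 8000 nM to 200000 nM, most likely reported again as a limit.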

Compound 4, half-maximal inhibitory concentration: > 30000 nM
Compound 4: no number, only a limit; the forecaster's own chance of this, stated with the estimate: 80%; the middle value lies beyond the limit too.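

Compound 3 and compound 4 each give only a limit, not a number, so no step can be read between them: the limit of > 30000 nM in this assay, at which 2 of the 4 values shown sit.

The compounds shown leave open how strongly either one inhibits, and what chloro in place of hydrogen on an aromatic carbon does to inhibition.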